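The source may hold more compounds than are shown below. What is called first, only, known or untested is meant among the compounds shown, and "the series" means these compounds.

Measured compounds in the series:

- compound 1, `CCc1ccc(C(=O)/C=C/C(=O)O)cc1` — 21000 nM
- compound 2, `O=C(O)/C=C/C(=O)c1ccc(Br)cc1` — 27100 nM
- compound 3, `O=C(O)/C=C/C(=O)c1cc(C2CCCCC2)ccc1C1CCCCC1` — 4280 nM

All three were tested in a functional assay on LS174T cells (Homo sapiens) for inhibition, read by MTT assay, with a stated time of 72 h; a lower number here means a stronger inhibitor, a higher number a weaker inhibitor. Compound 2 gives the highest number of the three. Compound 1 stands nearest to it, and the step of a 1.3-fold higher number from compound 1 to compound 2 (0.11 log units; within the scatter) shows that the two are indistinguishable in this assay. Going by the values given here, compound 3 gives a clearly lower number, a gap beyond the usual scatter, but compound 3 differs from compound 2 in more than one place and no single step connects them.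

The next compound, compound 4, `O=C(O)/C=C/C(=O)c1ccccc1`, is the unsubstituted parent. The change from compound 2 is hydrogen in place of bromo on an aromatic carbon.

Among the compounds with values here, only one measured step bears on this position: the swap of ethyl for bromo, a 1.3-fold higher number from compound 1 to compound 2 (0.11 log units; within the scatter), which stayed within the scatter. Two quite different groups at this position therefore gave the same number, and removing the group altogether is expected to matter little. Within the data shown here, no measured step shows what a bare hydrogen at this position does, so a modest rise in the number cannot be excluded.

The expected step is a 1.0-fold higher number from compound 2 to compound 4 (0.01 log units; within the scatter). Compound 4 is estimated at 28000 nM, with a range from 12000 nM to 65000 nM.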

Compound 4, half-maximal inhibitory concentration: 45500 nM
Beside the measured number, compound 4's estimate is 1.6-fold (0.21 log units) below it; low and high end bracket the measured number.
By their numbers in this assay, from the lowest: compound 3; then compounds 1, 2 and 4 (each within the scatter of the next, the first and the last beyond it).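

Going by these compounds alone, removing the group gives the first reading of a bare hydrogen at this position on the aromatic ring in this assay: a 1.7-fold higher number from compound 2 to compound 4 (0.23 log units; within the scatter), so hydrogen and bromo cannot be told apart here. Set against ethyl, the same hydrogen does separate, with a 2.2-fold higher number from compound 1 to compound 4 (0.34 log units; beyond the scatter), a modest step and the only one at this position that lies beyond the scatter; bromo sits within the scatter of both, so the position shows a small difference between its two outer members and no clear place for the group in the middle. No measurement on hand offers an explanation for this small difference between ethyl and hydrogen.

Still open, on these data alone, is whether an amine, a hydroxyl, a methoxy or a longer chain at this position would give a number clearly apart from those of ethyl, bromo and hydrogen, or stay in the same narrow band. Also open, as far as these compounds go, is whether the difference between ethyl and hydrogen would hold on repeated measurement, given how little it exceeds the scatter, and whether it would persist with a carboxylic acid or an amide placed on the same aromatic carbon.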